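Pyrazole for Oxetane on an Amide Nitrogen: Cold Receptor Agonists

The compounds below may be only part of what the source reports. "The series", "measured", "known", "first", "only" and "open" are said of these compounds alone.

Measured compounds:
compound 1 `Cc1ccc(OCC(=O)N(Cc2cccs2)C2COC2)cc1`, 23000 nM;
compound 2 `Cc1ccc(/C=C/C(=O)N(Cc2cccs2)c2ccn[nH]2)cc1`, 0.004 nM;
compound 3 `CCN(Cc1cn[nH]c1)C(=O)COc1ccc(C)cc1`, "active" (no number reported).

In an assay on HEK293 cells for agonist activity at transient receptor potential cation channel subfamily M member 8 (Homo sapiens), read by fluorescence and calcium flux, with a stated time of 15 min (a higher number here means that more compound is needed for the effect, a lower number that less compound is needed), compound 1 gives 23000 nM, the highest of the two numbers; compound 2 gives 0.004 nM, a gap far beyond the scatter, and compound 3 is reported only as "active" (no number reported). Compound 4 `Cc1ccc(OCC(=O)N(Cc2cccs2)c2ccn[nH]2)cc1` is not yet measured. It differs from compound 1 in one place: 1H-pyrazol-5-yl in place of oxetan-3-yl on an amide-type nitrogen. Compound 4 thus shares the 1H-pyrazol-5-yl of compound 2 on its amide-type nitrogen while keeping the rest of compound 1. Since compound 2 gives 0.004 nM, a large drop in the number is expected from compound 1, a 460-fold lower number from compound 1 to compound 4 (2.66 log units; beyond the scatter). Compound 4 is estimated at 50 nM, in the range 0.5 nM to 5000 nM.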

Compound 4, half-maximal effective concentration: 0.2 nM
Compound 4: middle estimate off by 250-fold (2.40 log units), on the high side; the whole stated range lies above it.
By their numbers in this assay, from the lowest: compound 2; then compound 4; then compound 1.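

With the rest of compound 1 unchanged, placing 1H-pyrazol-5-yl instead of oxetan-3-yl on the amide-type nitrogen gives, in this assay, a 120000-fold lower number from compound 1 to compound 4 (5.06 log units; beyond the scatter). Among these compounds, this single position therefore has a very large influence on the number, and the earlier compounds offered no such one-place comparison. Nothing measured here explains the size of this step.

Still open, on these data alone, is whether the ring's hydrogen-bond donor matters. A 1-methyl-1H-pyrazol-5-yl or a phenyl group on the same nitrogen would help to separate the donor from the aromatic ring.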